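Rearranging a dichlorophenyl group when every value is a limit

A few compounds are considered here, and "the series" means these few. Any claim that something is new, unique, unknown or untested is made for them only; others in the source may bear on it.

In a functional assay on A549 cells (Homo sapiens) for cytotoxicity, read by MTT assay, with a stated time of 72 h (on this read-out higher numbers stand for weaker inhibition and lower numbers for stronger inhibition), compound 1 (`COc1ccc(/C=C2\CCC/C(=C\c3ccccc3Cl)C2=O)cc1OC`) gives > 20000 nM, which is a limit and not a number. Compound 2 (`COc1ccc(/C=C2\CCC/C(=C\c3ccccc3Br)C2=O)cc1OC`) gives > 20000 nM, again a limit. Compound 3 (`COc1ccc(/C=C2\CCC/C(=C\c3ccc(Cl)cc3Cl)C2=O)cc1OC`) gives > 20000 nM, also a limit. All three therefore stand at one place: the limit of > 20000 nM in this assay, at which 3 of the 3 values shown sit.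

Compound 4 (`COc1ccc(/C=C2\CCC/C(=C\c3cc(Cl)cc(Cl)c3)C2=O)cc1OC`) carries 3,5-dichlorophenyl in place of 2,4-dichlorophenyl on a double-bonded chain carbon bound to a double-bonded ring carbon.

The closest measured changes are a step that the two limits leave unreadable from compound 1 to compound 3 and a step that the two limits leave unreadable from compound 2 to compound 3. Neither has a readable size, so neither gives a direction. In this assay, no change beyond the scatter is expected, and the estimated step is a step that the limit leaves unreadable from compound 3 to compound 4. Compound 4 is estimated at 25000 nM, with an expected range of 10000 nM to 60000 nM.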

Compound 4, half-maximal inhibitory concentration: 5500 nM
Compound 4: middle estimate off by 4.5-fold (0.66 log units), on the high side; measured number below the stated range.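

With the same atoms joined differently, 3,5-dichlorophenyl in place of 2,4-dichlorophenyl gives in this assay an at least 3.6-fold lower number from compound 3 to compound 4 (0.56 log units; beyond the scatter). The rings with a single halogen show the same gap: an at least 3.6-fold lower number from compound 2 to compound 4 (0.56 log units; beyond the scatter) and an at least 3.6-fold lower number from compound 1 to compound 4 (0.56 log units; beyond the scatter). At this position, then, where the halogens sit on the ring changes the result, not just whether they are there, and compound 4 alone leaves the shared limit: the limit of > 20000 nM in this assay, at which 3 of the 4 values shown sit.

As far as these compounds go, the steps among compound 1, compound 2 and compound 3 cannot be read, and the true size of each new step remains unknown. Also open, from the compounds shown here alone, is whether bromo or an amine on this ring would keep the gain.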